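A smaller thioether substituent on a shared core

The source may report more compounds than this note shows. Statements on the series, on what has been measured and on what is new or still open speak of the compounds shown alone.

Compound 1 `Cc1ccc(-c2nc(NN)c3cc(Cl)ccc3n2)cc1` and compound 2 `Cc1ccc(-c2nc(Sc3ncccc3[N+](=O)[O-])c3cc(Cl)ccc3n2)cc1` share the same core and differ only in the group attached to it. In a functional assay on HepG2 cells (Homo sapiens) for antiproliferative activity, read by MTT assay, with a stated time of 48 h (on this read-out lower numbers stand for stronger inhibition and higher numbers for weaker inhibition), compound 1 gives 4.17 ug/mL, and in this assay compound 2 gives 5.59 ug/mL. Compound 2 holds the higher of the two numbers, but the gap to compound 1 lies within the usual scatter of repeated measurements, so the two cannot be ranked against each other. Compound 3 `Cc1ccc(-c2nc(SCCO)c3cc(Cl)ccc3n2)cc1` follows from compound 2 by one change: 2-hydroxyethyl in place of 3-nitropyridin-2-yl on a sulfur. For the measured compounds named here, no measured pair of compounds shows a change of this kind, so the expectation rests only on the two values already in hand, which sit close together. The step from compound 2 to compound 3 is expected to be a 1.1-fold higher number from compound 2 to compound 3 (0.03 log units; within the scatter), not beyond the scatter in either direction. Compound 3 is therefore estimated to give 6 ug/mL, within a range from 2.5 ug/mL to 15 ug/mL.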

Compound 3, half-maximal inhibitory concentration: 9.04 ug/mL
Estimate against measurement, compound 3: 1.5-fold (0.18 log units) below; the measured number falls inside the stated range.
By their numbers in this assay, from the lowest: compounds 1, 2 and 3 (each within the scatter of the next, the first and the last beyond it).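

In this assay, a 3-nitropyridin-2-yl with an aromatic ring can be replaced on the sulfur by a 2-hydroxyethyl with no ring, and the result is a 1.6-fold higher number from compound 2 to compound 3 (0.21 log units; within the scatter) even though the two groups look very different. For the compounds shown here, compound 3 also gives the first step in this small set that clears the scatter, with (2-hydroxyethyl)sulfanyl in place of aminoamino on an aromatic carbon, namely a 2.2-fold higher number from compound 1 to compound 3 (0.34 log units; beyond the scatter) and still only a modest one. No measurement here accounts for either step.

The compounds shown leave open whether a longer chain or a carboxylic acid in place of 2-hydroxyethyl on the sulfur would move the number beyond the scatter. They also leave open how a simple amine would compare with aminoamino on the aromatic carbon.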